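The source may report more compounds than this note shows. Statements on the series, on what has been measured and on what is new or still open speak of the compounds shown alone.

In an ADME assay on RD cells (Homo sapiens) for cytotoxicity, read by neutral red uptake, with a stated time of 3 days (on this read-out higher numbers stand for lower toxicity in this test and lower numbers for higher toxicity in this test), compound 3 (`NNC(=O)c1cc(-c2ccccc2)nc2ccccc12`) gives > 300000 nM, which is a limit and not a number. Compound 1 (`CN(C)c1ccc(NC(=O)c2cc(-c3ccccc3)nc3ccccc23)cc1`) gives > 350000 nM, which is also a limit. Going by the values given here, compound 3 therefore has no readable number, and the only number belongs to compound 2 (`CC(C)Oc1cc(C(=O)NCCCN(C)C)c2ccccc2n1`), at 122000 nM.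

Compound 4 (`CN(C)CCCNC(=O)c1cc(-c2ccccc2)nc2ccccc12`) carries 3-(dimethylamino)propyl in place of amino on an amide-type nitrogen. Among the compounds with values here, the one measured step at that place is a step that the two limits leave unreadable from compound 1 to compound 3, so it sets no size. Compound 2 carries the same 3-(dimethylamino)propyl on its amide-type nitrogen and gives 122000 nM, so a move to a lower number in this assay is expected, with its size resting on that single value. The expected step is an at least 2.3-fold lower number from compound 3 to compound 4 (0.36 log units; beyond the scatter). Compound 4 is estimated at 130000 nM, with an expected range of 50000 nM to 300000 nM.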

Compound 4, half-maximal cytotoxic concentration: 44900 nM
Estimate against measurement, compound 4: 2.9-fold (0.46 log units) above, outside the stated range (below it).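

In this assay, the amide-type nitrogen now gives a readable change on the shared core, with 3-(dimethylamino)propyl in place of amino giving an at least 6.6-fold lower number from compound 3 to compound 4 (0.82 log units; beyond the scatter), and the same group in place of 4-(dimethylamino)phenyl giving an at least 7.7-fold lower number from compound 1 to compound 4 (0.89 log units; beyond the scatter). Both sizes are minimums: compound 3 and compound 1 each stand at a limit of the assay, not a number. With 3-(dimethylamino)propyl held on the amide-type nitrogen, the aromatic carbon also matters, as phenyl in place of isopropoxy gives a 2.7-fold lower number from compound 2 to compound 4 (0.43 log units; beyond the scatter).

Open, going by these compounds, is whether the lower number follows the dimethylamino group or the chain itself: 3-aminopropyl, 4-(dimethylamino)butyl or 3-carboxypropyl on the amide-type nitrogen would separate these. Also open, on these data alone, is whether a smaller alkoxy group such as methoxy on the aromatic carbon would behave like isopropoxy or like phenyl.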